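Extending the butyl chain of compound 3 by one carbon

A few compounds are considered here, and "the series" means these few. Any claim that something is new, unique, unknown or untested is made for them only; others in the source may bear on it.

The three measured compounds share one core and differ only in the chain on the aromatic oxygen. In an assay on isolated protein for inhibition of leukotriene B4 receptor 1 (Homo sapiens), tested at 10 uM (on this read-out higher numbers stand for more inhibition at the one concentration tested (going by the name of the read-out) and lower numbers for less inhibition), compound 1 `C=CCc1cc(C(C)=O)c(O)cc1OCCCCC#N` gives 92%, compound 2 `C=CCc1cc(C(C)=O)c(O)cc1OCCCCCC#N` gives 81%, and compound 3 `C=CCc1cc(C(C)=O)c(O)cc1OCCCC` gives 32%. Compound 3 stands lowest of the three: it lies a number 60 percentage points lower from compound 1 to compound 3 (beyond the scatter) and a number 49 percentage points lower from compound 2 to compound 3 (beyond the scatter), both large steps, so removing the nitrile from the chain end costs most of the inhibition.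

Compound 4 `C=CCc1cc(C(C)=O)c(O)cc1OCCCCC` differs from compound 3 by methyl in place of hydrogen on a saturated chain carbon, four bonds along the chain from an oxygen on an aromatic ring. Within the data shown here, the only measured step that lengthens the chain by one carbon is a number 11 percentage points lower from compound 1 to compound 2 (beyond the scatter), a modest loss that sits just beyond the scatter. Without a nitrile on the chain, the analogous extension from compound 3 to compound 4 is expected to move the number little, at most slightly downward.

Compound 4 is therefore estimated at 27% in this assay, within 12% to 45%, which corresponds to an expected step of a number 5 percentage points lower from compound 3 to compound 4 (within the scatter).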

Compound 4, a percentage reported as inhibition, at one concentration (the size of the read-out at that concentration, not a potency): 60%
Compound 4: middle estimate off by 33 percentage points, on the low side; measured number outside the range, above it.
By their numbers in this assay, from the lowest: compound 3; then compound 4; then compound 2; then compound 1.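

Without the nitrile, the added methyl at this place raises the number, with a number 28 percentage points higher from compound 3 to compound 4 (beyond the scatter), whereas the one-carbon extension of the nitrile chain went the other way, with a number 11 percentage points lower from compound 1 to compound 2 (beyond the scatter). Compound 4 still falls short of both nitrile compounds, with a number 21 percentage points lower from compound 2 to compound 4 (beyond the scatter) and a number 32 percentage points lower from compound 1 to compound 4 (beyond the scatter), so in this assay the nitrile keeps an advantage at both chain lengths shown. The size of that advantage depends on the chain, and removing the nitrile has no fixed cost: the same change on two cores in this assay, a number 60 percentage points lower (beyond the scatter) from compound 1 to compound 3 and a number 21 percentage points lower (beyond the scatter) from compound 2 to compound 4, 39 percentage points apart, beyond the scatter of two such steps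

Whether a longer chain without a nitrile would raise the number further or lower it remains open, since only one such extension is shown. Also open, on these data alone, is whether a carboxylic acid or an amine at the chain end could stand in for the nitrile.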